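Swapping the pyridin-3-yl group of compound 3

This account rests on a few compounds, and the source may have more. Where it says the series, first, only, none or still open, it means among the compounds named here.

Measured so far in an ADME assay on HCT-116 cells (Homo sapiens) for cytotoxicity, read by CellTiter-Glo, with a stated time of 72 h; on this read-out higher numbers stand for weaker inhibition and lower numbers for stronger inhibition (each value is a limit, not a number)
Compound 1 (`Cc1cc(C)c(S(=O)(=O)N2CCC(N3CCC(c4ccccc4)CC3)CC2)c(C)c1`) gives > 5000 nM (a limit)
Compound 2 (`CC1CCN(C2CCN(S(=O)(=O)c3ccc(C#N)cc3)CC2)CC1`) gives > 5000 nM (a limit)
Compound 3 (`CC1CCN(C2CCN(S(=O)(=O)c3cccnc3)CC2)CC1`) gives > 10000 nM (a limit)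

Compound 3 has only a limit (> 10000 nM) and no exact number. Compound 4 (`CC1CCN(C2CCN(S(=O)(=O)c3cnc(Cl)s3)CC2)CC1`) has 2-chloro-1,3-thiazol-5-yl in place of pyridin-3-yl on a sulfonyl sulfur. Among the compounds with values here, the one measured step at this place (a step that the two limits leave unreadable from compound 2 to compound 3) has no readable size, so it offers no size to carry over. With no measured number to suggest a shift, no step beyond the scatter is expected in this assay (a number no higher from compound 3 to compound 4 (the limit leaves the size open)). Compound 4 is expected at 10000 nM with a range from 4000 nM to 20000 nM (possibly reported as a limit again).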

Compound 4, half-maximal inhibitory concentration: > 10000 nM
Compound 4 was reported as a limit; the forecaster's own chance of this, stated with the estimate: 75%; the middle value lies on the limit itself.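

Within the data shown here, compound 4 gives > 10000 nM, which is a limit, so no step from compound 2 or compound 3 to compound 4 can be read. The compounds shown leave open whether changing the group on the sulfonyl sulfur shifts the read-out at all.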